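Moving the Pyridine Link in an Isomer of Compound 2

The source may report more compounds than this note shows. Statements on the series, on what has been measured and on what is new or still open speak of the compounds shown alone.

In a physicochemical assay for solubility, read by chemiluminescence, measured as kinetic solubility (a higher number here means a more soluble compound, a lower number a less soluble compound), compound 1 `COc1cccc2c1c(NS(=O)(=O)c1ccc(Cl)s1)nn2Cc1cccc(CNC(=O)C2CCOCC2)c1` gives >= 193 ug/mL, a limit of the assay and not a number. Compound 2 `COc1cccc2c1c(NS(=O)(=O)c1ccc(Cl)s1)nn2Cc1cc(CNC(C)=O)ccn1` gives >= 141 ug/mL, also a limit and not a number. So the position of compound 2 is only partly known, since neither of the two results is an exact reading, and no measured step connects the two compounds.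

Compound 3 `COc1cccc2c1c(NS(=O)(=O)c1ccc(Cl)s1)nn2Cc1ccnc(CNC(C)=O)c1` has the same atoms as compound 2, joined differently: 2-(acetamidomethyl)pyridin-4-yl in place of 4-(acetamidomethyl)pyridin-2-yl on a saturated chain carbon bound to an aromatic nitrogen. Put simply, 2-(acetamidomethyl)pyridin-4-yl stands in place of 4-(acetamidomethyl)pyridin-2-yl on a saturated chain carbon bound to an aromatic nitrogen. The two groups count the same, so the swap alters only how they are connected.

For the measured compounds named here, with no measured step as a guide, the expected change has no clear direction. A step of a number no higher from compound 2 to compound 3 (the limit leaves the size open) is expected to stay within the usual scatter. This expectation rests on the limit of compound 2 at >= 141 ug/mL. Compound 3 is estimated at 140 ug/mL. The expected range for compound 3 runs from 70 ug/mL to 175 ug/mL.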

Compound 3, solubility: >= 161 ug/mL
Compound 3: no number, only a limit; the forecaster's own chance of this, stated with the estimate: 65%; middle value at least 1.1-fold (0.06 log units) away from the limit.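

In this assay, for the compounds shown here, compound 2 and compound 3 each give a limit and not a number, so no step between them can be read. The compounds shown leave open whether 2-(acetamidomethyl)pyridin-4-yl in place of 4-(acetamidomethyl)pyridin-2-yl changes the solubility reading at all and, if it does, in which direction and by how much.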